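The compounds below may be only part of what the source reports. "The series", "measured", "known", "first", "only" and "open" are said of these compounds alone.

Working notes on the series. Compound 1 `N#Cc1ccc(C(c2ccc(C#N)cc2)n2cc(COc3ccccc3)nn2)cc1` in an assay on isolated protein for inhibition of Aromatase (Homo sapiens), read by fluorescence and colorimetric assay, with a stated time of 30 min (a higher number here means a weaker inhibitor, a lower number a stronger inhibitor), gives 11000 nM. Compound 2 `N#Cc1ccc(OCc2cn(C(c3ccc(C#N)cc3)c3ccc(C#N)cc3)nn2)cc1` in this assay gives 4640 nM, and compound 3 `N#Cc1ccc(C(c2ccc(C#N)cc2)n2cc(COc3ccc(-c4ccccc4)cc3)nn2)cc1` gives 13400 nM. Compound 1 thus stands second highest of the three numbers: its nearest neighbour is compound 3, with a 1.2-fold higher number from compound 1 to compound 3 (0.09 log units; within the scatter), within the scatter, whereas a 2.4-fold lower number from compound 1 to compound 2 (0.37 log units; beyond the scatter) lies beyond it. The remaining measured step, a 2.9-fold higher number from compound 2 to compound 3 (0.46 log units; beyond the scatter), is also modest. All three measured steps alter the group on an aromatic carbon of the phenoxy ring and leave the shared core untouched.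

Compound 4 `N#Cc1ccc(Cn2cc(COc3ccccc3)nn2)cc1` differs from compound 1 at another place: hydrogen in place of 4-cyanophenyl on a saturated chain carbon bound to an aromatic carbon and an aromatic nitrogen. Within the data shown here, no measured step touches that chain carbon, so none of the three steps bears directly on it; they show only that changes at the phenoxy ring move the number modestly. The change to compound 4 removes an aromatic ring from the core itself, a larger alteration than any measured one. A weaker inhibitor is expected, with wide uncertainty: for compound 4 the estimate is 40000 nM (range 8000 nM to 200000 nM), which corresponds to an expected step of a 3.6-fold higher number from compound 1 to compound 4 (0.56 log units; beyond the scatter).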

Compound 4, half-maximal inhibitory concentration: 6090 nM
Beside the measured number, compound 4's estimate is 6.6-fold (0.82 log units) above it; the measured number lies below the stated range.
By their numbers in this assay, from the lowest: compounds 2, 4, 1 and 3 (each within the scatter of the next, the first and the last beyond it).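

Replacing 4-cyanophenyl with hydrogen on the saturated chain carbon bound to an aromatic carbon and an aromatic nitrogen gives a 1.8-fold lower number from compound 1 to compound 4 (0.26 log units; within the scatter) in this assay. Among these compounds, this is the first reading at that carbon, and it shows that a loss of 8 heavy atoms, including one six-membered aromatic ring of carbon only, need not shift the number beyond the scatter, so this 4-cyanophenyl is not required to hold the number of compound 1. No available evidence bears on why the number holds after this change.

Going by these compounds, whether the same replacement would leave the numbers of compound 2 and compound 3 within the scatter stays open. Also open, on these data alone, is how other groups on that chain carbon, such as methyl or an unsubstituted phenyl, would compare with 4-cyanophenyl and hydrogen.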